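Replacing a fluorophenyl with a pyridinyl ring

The source may hold more compounds than are shown below. What is called first, only, known or untested is meant among the compounds shown, and "the series" means these compounds.

The three measured compounds share one core and differ only on an amine nitrogen in a ring. In a functional assay on A-375 cells (Homo sapiens) for antiproliferative activity, read by CCK-8 assay, with a stated time of 72 h, tested at 8 uM (on this read-out lower numbers stand for a weaker effect and higher numbers for a stronger effect at the one concentration tested), compound 1 `Nc1ccccc1NC(=O)c1ccc(CSC(=S)N2CCN(c3ccccc3)CC2)cc1` gives 88.6%, compound 2 `Nc1ccccc1NC(=O)c1ccc(CSC(=S)N2CCN(Cc3cccnc3)CC2)cc1` gives 89.2%, and compound 3 `Nc1ccccc1NC(=O)c1ccc(CSC(=S)N2CCN(c3ccccc3F)CC2)cc1` gives 79.5%. Compound 3 holds the lowest of the three numbers, yet a number 9.1 percentage points lower from compound 1 to compound 3 (within the scatter) and a number 9.7 percentage points lower from compound 2 to compound 3 (within the scatter) both lie within the scatter, as does a number 0.6 percentage points higher from compound 1 to compound 2 (within the scatter). Compound 4 `Nc1ccccc1NC(=O)c1ccc(CSC(=S)N2CCN(c3ccncc3)CC2)cc1` differs from compound 3 by pyridin-4-yl in place of 2-fluorophenyl on an amine nitrogen in a ring. For the measured compounds named here, no measured step matches this exact exchange; the three steps that bear on it all stayed within the scatter, so no step beyond the scatter is expected in this assay. The estimate for compound 4 is 85%, between 72% and 95%, an expected step of a number 5.5 percentage points higher from compound 3 to compound 4 (within the scatter).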

Compound 4, a percentage reported as inhibition, at one concentration (the size of the read-out at that concentration, not a potency): 90.7%
Compound 4: the middle estimate sits 5.7 percentage points below what was measured; the range from low to high includes it.
By their numbers in this assay, from the lowest: compounds 3, 1, 2 and 4 (each within the scatter of the next, the first and the last beyond it).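

In this assay, for the compounds shown here, the exchange of 2-fluorophenyl for pyridin-4-yl gives a number 11.2 percentage points higher from compound 3 to compound 4 (beyond the scatter) and is the first step beyond the scatter at this amine nitrogen. The other two steps, a number 1.5 percentage points higher from compound 2 to compound 4 (within the scatter) and a number 2.1 percentage points higher from compound 1 to compound 4 (within the scatter), leave pyridin-4-yl indistinguishable from (pyridin-3-yl)methyl and phenyl. No evidence at hand accounts for the larger step.

On these data alone, compound 3 and compound 4 differ in both the fluoro group and the ring nitrogen, so which of these matters stays open. As far as these compounds go, how an acetyl group or a longer alkyl chain would read at this nitrogen also stays open.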